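From a Free Ring Amine to an Isobutyl Group

This account rests on a few compounds, and the source may have more. Where it says the series, first, only, none or still open, it means among the compounds named here.

Three measured compounds share one core and differ only in the ring carried on the sulfonyl group. In an assay on HeLa cells for displacement of a labelled ligand from 5-hydroxytryptamine receptor 6 (Homo sapiens) (on this read-out lower numbers stand for stronger inhibition and higher numbers for weaker inhibition), compound 1 `O=S(=O)(c1ccc(C(F)(F)F)cc1)c1cccc2oc(N3CCNCC3)nc12` gives 33 nM, compound 2 `O=S(=O)(c1cc(Cl)ccc1Cl)c1cccc2oc(N3CCNCC3)nc12` gives 13 nM, and compound 3 `O=S(=O)(c1cccc2ccccc12)c1cccc2oc(N3CCNCC3)nc12` gives 3.1 nM, the lowest of the three numbers; its gap to compound 2 and its larger gap to compound 1 both lie beyond the usual scatter. Compound 4 `CC(C)CN1CCN(c2nc3c(S(=O)(=O)c4cccc5ccccc45)cccc3o2)CC1` keeps everything in compound 3 and changes one place: isobutyl in place of hydrogen on an amine nitrogen in a ring, so piperazin-1-yl becomes 4-isobutylpiperazin-1-yl. For the measured compounds named here, no measured pair shows this change, so its size is unknown. A modest weakening, a 2.6-fold higher number from compound 3 to compound 4 (0.41 log units; beyond the scatter), is expected. Compound 4 is estimated at 8 nM, within a range from 2 nM to 30 nM.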

Compound 4, inhibition constant: 176 nM
Estimate against measurement, compound 4: 22-fold (1.34 log units) below; the whole stated range lies below it.
By their numbers in this assay, from the lowest: compound 3; then compound 2; then compound 1; then compound 4.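

The earlier compounds shown here all carry hydrogen on this ring nitrogen, so they could not show how much it matters. In this assay isobutyl there gives a 57-fold higher number from compound 3 to compound 4 (1.75 log units; beyond the scatter), a large loss that shows this position does not accept every group without cost. Nothing measured here explains the loss.

On these data alone, whether a shorter group such as methyl, or a chain ending in a hydroxyl group, would lose as much remains open. So does whether isobutyl would cost as much with the other rings on the sulfonyl group.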